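Sulfonate esters: swapping an isobutyramide for an ethylurea

A few compounds are considered here, and "the series" means these few. Any claim that something is new, unique, unknown or untested is made for them only; others in the source may bear on it.

Compound 1 `CC(=O)Nc1cccc(S(=O)(=O)Oc2ccccc2C(C)C)c1`: 27000 nM
Compound 2 `CC(C)C(=O)Nc1ccc(S(=O)(=O)Oc2ccccc2C(C)C)cc1`: 14000 nM
Compound 3 `CC(C)C(=O)Nc1ccc(S(=O)(=O)Oc2ccccc2I)cc1`: 13000 nM

All three were tested in a functional assay on HT-29 cells (Homo sapiens) for antiproliferative activity, read by sulforhodamine B assay, with a stated time of 48 h; a lower number here means a stronger inhibitor, a higher number a weaker inhibitor. Compound 2 sits second highest among the three numbers: compound 3 is nearest, with a 1.1-fold lower number from compound 2 to compound 3 (0.03 log units; within the scatter), and compound 1 furthest, its value and that of compound 2 lying within the scatter of each other. Compound 4 `CCNC(=O)Nc1ccc(S(=O)(=O)Oc2ccccc2C(C)C)cc1` has not been measured. It differs from compound 2 by ethylamino in place of isopropyl on a carbonyl carbon. Going by the values given here, the only single-site step measured so far, a 1.1-fold lower number from compound 2 to compound 3 (0.03 log units; within the scatter), concerns the other ring and says nothing about changes at the carbonyl carbon. Without a guiding step, compound 4 is expected to stay close to compound 2, with no change at the digits printed from compound 2 to compound 4 (within the scatter) as the estimated step. The estimate for compound 4 is 14000 nM, expected between 5000 nM and 40000 nM.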

Compound 4, half-maximal inhibitory concentration: 1100 nM
Compound 4: the middle estimate sits 13-fold (1.10 log units) above what was measured; the measured number lies below the stated range.
By their numbers in this assay, from the lowest: compound 4; then compounds 3, 2 and 1 (each within the scatter of the next, the first and the last beyond it).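

Going by these compounds alone, the carbonyl carbon proves a sensitive place in this assay: ethylamino in place of isopropyl gives a 13-fold lower number from compound 2 to compound 4 (1.10 log units; beyond the scatter), whereas the only earlier single-place step, a 1.1-fold lower number from compound 2 to compound 3 (0.03 log units; within the scatter), lay within the scatter and concerned a different site. This swap keeps the count of three heavy atoms yet adds one hydrogen-bond donor, though whether that donor matters cannot be told from these compounds. Nothing available explains the size of this step. Open questions are how a methylamino or propylamino group would fare on the same carbonyl carbon, and whether the iodo group of compound 3 would keep this level alongside ethylamino.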